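Hydroxy to chloro on the aryl ketone: expectation

The source may report more compounds than this note shows. Statements on the series, on what has been measured and on what is new or still open speak of the compounds shown alone.

Among the measured compounds shown here, compound 2 `O=C(/C=C/c1cc2ccccc2[nH]c1=O)c1ccc(O)cc1` gives 2390 nM in a functional assay on NCI-H460 cells (Homo sapiens) for cytotoxicity, read by sulforhodamine B assay, with a stated time of 24 h (on this read-out higher numbers stand for weaker inhibition of growth and lower numbers for stronger inhibition of growth), and stands level with compound 1 `COc1ccc(C(=O)/C=C/c2cc3ccccc3[nH]c2=O)cc1`, which in this assay gives 2750 nM; the single measured step, a 1.2-fold lower number from compound 1 to compound 2 (0.06 log units; within the scatter), is within the scatter. Compound 3 `O=C(/C=C/c1cc2ccccc2[nH]c1=O)c1ccc(Cl)cc1` is to be measured in this assay and differs from compound 2 by chloro in place of hydroxy on an aromatic carbon. For the measured compounds named here, the only measured step touches the same place on the ring, but it swaps hydrogen for methyl on the oxygen and leaves the oxygen in place, so it bears on the new change only loosely: it shows that this place tolerated a small edit without a shift beyond the scatter. Going by the values given here, no measured step removes the oxygen group or introduces chloro here. The step from compound 2 to compound 3 is therefore expected to be small, a 1.2-fold lower number from compound 2 to compound 3 (0.08 log units; within the scatter), with direction uncertain. Compound 3 is estimated at 2000 nM, in the range 700 nM to 6000 nM.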

Compound 3, concentration for 50% growth inhibition: 3990 nM
For compound 3 the middle estimate is 2.0-fold (0.30 log units) below the measured one; low and high end bracket the measured number.
By their numbers in this assay, from the lowest: compounds 2, 1 and 3 (each within the scatter of the next).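

In this assay the step that takes the oxygen off this place altogether stays within the scatter (a 1.7-fold higher number from compound 2 to compound 3 (0.22 log units; within the scatter)), and so does the step from methoxy to chloro (a 1.5-fold higher number from compound 1 to compound 3 (0.16 log units; within the scatter)). The earlier pair changed only what sits on the oxygen, whereas here hydroxy, counted with a hydrogen-bond donor and a hydrogen-bond acceptor, gives way to chloro, counted with neither, with no shift beyond the scatter. No measurement at hand offers an explanation for this result.

The compounds shown leave open whether an amine or a carboxylic acid at this place, or a longer chain on the oxygen, would move the number beyond the scatter. They also leave open whether the same hydroxy to chloro change would stay within the scatter elsewhere on the aromatic ring.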